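Ester-end variation and gastric half-life in the series

The source may report more compounds than this note shows. Statements on the series, on what has been measured and on what is new or still open speak of the compounds shown alone.

Compound 3 `CCOc1cc(NC(=O)C2(NC(=O)c3ccc4c(C5CCCC5)c(-c5ncc(Cl)cn5)n(C)c4c3)CCC2)ccc1/C=C/C(=O)OCC(Cl)(Cl)Cl` stands highest of the three numbers in an ADME assay on stomach for pharmacokinetics, in simulated gastric fluid (a lower number here means that the compound disappears faster, a higher number that the compound lasts longer), where compound 3 gives 1.75 h. Compound 1 `CCOc1cc(NC(=O)C2(NC(=O)c3ccc4c(C5CCCC5)c(-c5ncc(Cl)cn5)n(C)c4c3)CCC2)ccc1/C=C/C(=O)N[C@@H](CCC(=O)O)C(N)=O` gives 0.533 h in this assay, and compound 2 `CCOc1cc(NC(=O)C2(NC(=O)c3ccc4c(C5CCCC5)c(-c5ncc(Cl)cn5)n(C)c4c3)CCC2)ccc1/C=C/C(=O)N[C@@H](CCCNC(=N)N)C(N)=O` gives 0.467 h; the step of a 1.1-fold lower number from compound 1 to compound 2 (0.06 log units; within the scatter) lies within the scatter. The steps of a 3.3-fold higher number from compound 1 to compound 3 (0.52 log units; beyond the scatter) and a 3.7-fold higher number from compound 2 to compound 3 (0.57 log units; beyond the scatter) both exchange an amide end of the chain for the ester end that compound 3 carries, and both are modest but beyond the scatter. Compound 4 `CCOc1cc(NC(=O)C2(NC(=O)c3ccc4c(C5CCCC5)c(-c5ncc(Cl)cn5)n(C)c4c3)CCC2)ccc1/C=C/C(=O)OCC(=O)N1CCOCC1` keeps that ester and differs from compound 3 by (morpholin-4-yl)carbonyl in place of trichloromethyl on a saturated chain carbon bound to an oxygen next to a carbonyl group. Among the compounds with values here, no measured step exchanges a group on this saturated chain carbon while the ester is retained, so the two steps into compound 3 give only a bracket: the ester compound sits apart from the two amides. The number for compound 4 is therefore expected to remain nearer compound 3 than the amides. The expected step is a 1.6-fold lower number from compound 3 to compound 4 (0.20 log units; within the scatter), small enough that it may fall within the scatter. Compound 4 is estimated at 1.1 h in this assay, in a range of 0.45 h to 2.6 h.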

Compound 4, half-life: 0.85 h
For compound 4 the middle estimate is 1.3-fold (0.11 log units) above the measured one; measured number inside the range.
By their numbers in this assay, from the lowest: compounds 2, 1 and 4 (each within the scatter of the next); then compound 3.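

In this assay, the saturated chain carbon bound to an oxygen next to a carbonyl group now has a readable step with the ester retained: (morpholin-4-yl)carbonyl in place of trichloromethyl lowers the number (a 2.1-fold lower number from compound 3 to compound 4 (0.31 log units; beyond the scatter)). The ester end alone therefore does not separate a compound from the amides, as compound 4 stays within the scatter of both (a 1.8-fold higher number from compound 2 to compound 4 (0.26 log units; within the scatter); a 1.6-fold higher number from compound 1 to compound 4 (0.20 log units; within the scatter)), and among these four only compound 3 stands apart. Nothing available explains this step.

Within the data shown here, with only two groups compared on this carbon, it remains open how a plain methyl, an amine or a carboxylic acid there would read with the ester retained. Also open, going by these compounds, is whether a single chlorine or a longer chain in place of trichloromethyl would stay near compound 3 or fall towards compound 4.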